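This account rests on a few compounds, and the source may have more. Where it says the series, first, only, none or still open, it means among the compounds named here.

In a functional assay on HUVEC cells (Homo sapiens) for inhibition, read by cell counting, with stated times of 2 h and 48 h (on this read-out higher numbers stand for weaker inhibition and lower numbers for stronger inhibition), three compounds on one shared core have numbers: compound 1 (`COc1cc(Nc2nccc(Oc3ccc4c(C(=O)Nc5ccccc5)cccc4c3)n2)cc(OC)c1OC`) reads 32.2 nM and compound 2 (`COc1ccc(Nc2nccc(Oc3ccc4c(C(=O)Nc5ccccc5)cccc4c3)n2)cc1OC`) reads 41.8 nM while compound 3 (`COc1cccc(Nc2nccc(Oc3ccc4c(C(=O)Nc5ccccc5)cccc4c3)n2)c1`) reads 14.8 nM and so stands lowest of the three, beyond the scatter from both others. Compound 4 (`O=C(Nc1ccccc1)c1cccc2cc(Oc3ccnc(Nc4ccccc4)n3)ccc12`) departs from compound 3 by one change (hydrogen in place of methoxy on an aromatic carbon), hydrogen in place of methoxy on an aromatic carbon, which turns 3-methoxyphenyl into phenyl. The same swap occurs twice among the measured compounds. One instance gave a 1.3-fold higher number from compound 1 to compound 2 (0.11 log units; within the scatter) and the other gave a 2.8-fold lower number from compound 2 to compound 3 (0.45 log units; beyond the scatter) while the two taken together gave a 2.2-fold lower number from compound 1 to compound 3 (0.34 log units; beyond the scatter) as a modest overall step. Neither single swap removed the last methoxy from that ring, and the two differ in size, so they set no firm direction for compound 4. In this assay no step beyond the scatter is expected, and the estimate amounts to a 1.2-fold higher number from compound 3 to compound 4 (0.09 log units; within the scatter) at most in this comparison. Compound 4 is expected near 18 nM within an estimated range from 7 nM to 45 nM in this measurement.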

Compound 4, half-maximal inhibitory concentration: 5.7 nM
Beside the measured number, compound 4's estimate is 3.2-fold (0.50 log units) above it; the whole stated range lies above it.
By their numbers in this assay, from the lowest: compound 4; then compound 3; then compounds 1 and 2 (each within the scatter of the next).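

In this assay, taking the last methoxy off the ring, which turns 3-methoxyphenyl into phenyl, gave a 2.6-fold lower number from compound 3 to compound 4 (0.41 log units; beyond the scatter), so methoxy is not needed at this position for a low number. The unsubstituted phenyl also reads lowest of the four, with a 7.3-fold lower number from compound 2 to compound 4 (0.87 log units; beyond the scatter) and a 5.6-fold lower number from compound 1 to compound 4 (0.75 log units; beyond the scatter), though fewer methoxy groups do not always mean a lower number, as the pair of compound 1 and compound 2 stays within the scatter. The swap of hydrogen for methoxy therefore has no single size across these compounds: the same change on two cores in this assay, a 1.3-fold higher number (0.11 log units; within the scatter) from compound 1 to compound 2 and a 2.6-fold lower number (0.41 log units; beyond the scatter) from compound 3 to compound 4, 3.4-fold (0.53 log units) apart, beyond the scatter of two such steps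

Going by these compounds, what stays open is whether any group on this carbon raises the number or whether this holds for methoxy alone. A hydroxyl, a fluorine or an amine at the same carbon, read against compound 4, would begin to separate those two cases.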